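This account rests on a few compounds, and the source may have more. Where it says the series, first, only, none or still open, it means among the compounds named here.

Of the compounds shown here, three share one core and have been measured in a functional assay on COLO 205 cells (Homo sapiens) for cytotoxicity, read by MTT assay, with a stated time of 24 h; on this read-out lower numbers stand for stronger inhibition and higher numbers for weaker inhibition. Compound 1 `COc1ccccc1-n1cc(COc2c(/C=C\C(=O)O)ccc(OC)c2CC=C(C)C)nn1` gives 12200 nM in this assay. Compound 2 `COc1ccc(/C=C\C(=O)O)c(OCc2cn(-c3ccccc3F)nn2)c1CC=C(C)C` gives 14500 nM. Compound 3 `COc1ccc(/C=C\C(=O)O)c(OCc2cn(-c3ccccc3)nn2)c1CC=C(C)C` gives 32300 nM, the highest of the three numbers: the steps of a 2.6-fold higher number from compound 1 to compound 3 (0.42 log units; beyond the scatter) and a 2.2-fold higher number from compound 2 to compound 3 (0.35 log units; beyond the scatter) both lie beyond the scatter, whereas the step of a 1.2-fold higher number from compound 1 to compound 2 (0.08 log units; within the scatter) lies within it. So replacing a methoxy or a fluoro by hydrogen on that aromatic carbon raised the number modestly, while exchanging methoxy for fluoro made no difference that can be trusted.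

Compound 4 `COc1ccc(/C=C\C(=O)O)c(OCc2cn(-c3ccccc3C(=O)N3CCC(O)C3)nn2)c1CC=C(C)C` is the next one to be measured. It differs from compound 3 in one place: (3-hydroxypyrrolidin-1-yl)carbonyl in place of hydrogen on an aromatic carbon. The two steps that bear on this change, from compound 1 and from compound 2 to compound 3, show that putting a substituent on this aromatic carbon lowered the number by a modest amount. The group entering in compound 4 is far larger than either, so these steps only loosely inform what happens here. The expected step of a 2.3-fold lower number from compound 3 to compound 4 (0.36 log units; beyond the scatter) is therefore a modest lowering of the number, with wide uncertainty. Compound 4 is expected to give about 14000 nM in this assay, within a range from 4500 nM to 45000 nM.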

Compound 4, half-maximal inhibitory concentration: 25400 nM
Estimate against measurement, compound 4: 1.8-fold (0.26 log units) below; low and high end bracket the measured number.
By their numbers in this assay, from the lowest: compounds 1, 2, 4 and 3 (each within the scatter of the next, the first and the last beyond it).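

In this assay, the (3-hydroxypyrrolidin-1-yl)carbonyl group on this aromatic carbon, ortho to a large group, leaves the number indistinguishable from that of the compound bearing hydrogen, with a 1.3-fold lower number from compound 3 to compound 4 (0.10 log units; within the scatter), so the modest lowering seen with methoxy and fluoro does not carry over to every substituent at this place. The comparison with fluoro, a 1.8-fold higher number from compound 2 to compound 4 (0.24 log units; within the scatter), also gives no reliable difference, whereas the comparison with methoxy, a 2.1-fold higher number from compound 1 to compound 4 (0.32 log units; beyond the scatter), shows that among these two groups and hydrogen only methoxy retains a modest advantage over the new group, and the position nonetheless accepts a group of this size with no measurable penalty relative to hydrogen. Nothing available accounts for why the new group behaves as it does here.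

The compounds shown leave open whether the hydroxyl on the new group matters, since the same carbonyl group with a plain pyrrolidine ring does not appear among them. They also leave open how a small amine, a carboxylic acid or a second methoxy on this ring would compare with the methoxy of compound 1.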